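The compounds below may be only part of what the source reports. "The series", "measured", "known", "first", "only" and "open" are said of these compounds alone.

In a functional assay on MDA-MB-231 cells (Homo sapiens) for antiproliferative activity, read by sulforhodamine B assay, with a stated time of 72 h (a higher number here means a weaker inhibitor, a lower number a stronger inhibitor), three compounds sharing one core have been measured. Compound 1 `Cc1ccc(O)c(C(=O)/C=C/c2csc3ccccc23)c1` gives 6000 nM, and compound 3 `CCOc1ccc(O)c(C(=O)/C=C/c2csc3ccccc23)c1` gives 6700 nM. Compound 2 `COc1ccc(O)c(C(=O)/C=C/c2csc3ccccc23)c1`, which carries a methoxy group where those two carry methyl and ethoxy, gives 760 nM, the lowest number of the three.

Compound 4 `COc1cc(O)c(C(=O)/C=C/c2csc3ccccc23)cc1OC` keeps that methoxy group and gains a second one: methoxy in place of hydrogen on an aromatic carbon. This is methoxy in place of hydrogen on an aromatic carbon, ortho to a methoxy group, meta to a hydroxy group and para to a large group.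

Among the measured compounds shown here, no measured step makes this exact change, so the evidence is indirect. Swapping the single group gives a 7.9-fold lower number from compound 1 to compound 2 (0.90 log units; beyond the scatter) and an 8.8-fold higher number from compound 2 to compound 3 (0.95 log units; beyond the scatter), both modest but beyond the scatter, while a 1.1-fold higher number from compound 1 to compound 3 (0.05 log units; within the scatter) stays within it. Compound 2 therefore looks like a narrow optimum among three compounds, and a small addition to it can matter. A move toward a higher number is expected, estimated as a 2.6-fold higher number from compound 2 to compound 4 (0.42 log units; beyond the scatter). The estimate for compound 4 is 2000 nM, with an expected range of 600 nM to 7000 nM.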

Compound 4, half-maximal inhibitory concentration: 690 nM
For compound 4 the middle estimate is 2.9-fold (0.46 log units) above the measured one, and the stated range covers the measured number.
By their numbers in this assay, from the lowest: compounds 4 and 2 (each within the scatter of the next); then compounds 1 and 3 (each within the scatter of the next).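

In this assay the added methoxy group, ortho to a methoxy group, meta to a hydroxy group and para to a large group, gives a 1.1-fold lower number from compound 2 to compound 4 (0.04 log units; within the scatter) and so leaves the number within the scatter. This aromatic carbon therefore accepts a methoxy group in place of hydrogen without a change this assay can separate, whereas exchanging the methoxy group of compound 2 for methyl or ethoxy gave steps beyond the scatter. No measurement available here accounts for this tolerance.

Methoxy is the only group shown at this carbon, so it remains open whether a longer chain, an amine or a carboxylic acid would also leave the number within the scatter. Going by these compounds, it also remains open whether hydrogen here could be replaced by a group that gives a clearly lower number.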